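The source may report more compounds than this note shows. Statements on the series, on what has been measured and on what is new or still open speak of the compounds shown alone.

Compound 3 `NC1CCN(c2ccc3cc(NC(=O)CCc4ccc(C(F)(F)F)cc4)ccc3n2)C1` carries a 3-aminopyrrolidin-1-yl group on the shared core and, in an assay on isolated protein for displacement of a labelled ligand from melanin-concentrating hormone receptor 1 (Homo sapiens) (on this read-out lower numbers stand for stronger inhibition and higher numbers for weaker inhibition), compound 3 gives 12 nM, the highest of the two single numbers available. Its nearest neighbour is compound 1 `CC(C)N(C)c1ccc2cc(NC(=O)CCc3ccc(C(F)(F)F)cc3)ccc2n1`, which in this assay gives 2 nM; the step of a 6.0-fold higher number from compound 1 to compound 3 (0.78 log units; beyond the scatter) exchanges the isopropyl(methyl)amino group for the 3-aminopyrrolidin-1-yl group. Compound 2 `O=C(CCc1ccc(C(F)(F)F)cc1)Nc1ccc2nc(N3CCCC3)ccc2c1` bears a pyrrolidin-1-yl group at the same position and in this assay compound 2 gives 3 nM; 3 nM (2 entries) in each of two entries.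

Compound 4 `O=C(CCc1ccc(C(F)(F)F)cc1)Nc1ccc2nc(N3CCCCCC3)ccc2c1` differs from compound 3 in one place: azepan-1-yl in place of 3-aminopyrrolidin-1-yl on an aromatic carbon. Within the data shown here, the single measured step bears on this change only indirectly, in that the one compound with a hydrogen-bond donor on the amine substituent, compound 3, stands higher than the two without one. On that basis the number for compound 4 is expected to move downward, with a step of about a 4.0-fold lower number from compound 3 to compound 4 (0.60 log units; beyond the scatter). Compound 4 is therefore estimated at 3 nM, with a likely range from 1 nM to 10 nM.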

Compound 4, half-maximal inhibitory concentration: 36 nM
Compound 4: the middle estimate sits 12-fold (1.08 log units) below what was measured; the whole stated range lies below it.
By their numbers in this assay, from the lowest: compound 1; then compound 3; then compound 4.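

With azepan-1-yl in this position, the number rises again, a 3.0-fold higher number from compound 3 to compound 4 (0.48 log units; beyond the scatter), so compound 3 is no longer the highest and a group with 0 hydrogen-bond donors does not by itself keep the number low. Among these compounds, the change from isopropyl(methyl)amino gives an 18-fold higher number from compound 1 to compound 4 (1.26 log units; beyond the scatter), the only step here graded large, and the printed values separate the two cyclic groups without a donor: compound 2, with pyrrolidin-1-yl, gives 3 nM; 3 nM (2 entries), while compound 4, with its seven-membered ring, gives 36 nM. No measured evidence accounts for these differences.

The compounds shown leave open where piperidin-1-yl, the six-membered ring, would stand relative to pyrrolidin-1-yl and azepan-1-yl. They also leave open whether an amine on the azepane ring, or a morpholin-4-yl group, would shift the number in either direction.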